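The compounds below may be only part of what the source reports. "The series", "measured", "known", "first", "only" and "open" are said of these compounds alone.

- Compound 1 `CNCC(=O)Nc1cc(OC)ccc1C(=O)c1ccc2c(c1)C=CC(C)(C)O2`: 970 nM
- Compound 2 `CCNCC(=O)Nc1cc(OC)ccc1C(=O)c1ccc2c(c1)C=CC(C)(C)O2`: 3110 nM

In a functional assay on HeLa cells (Homo sapiens) for antiproliferative activity, read by MTT assay, with a stated time of 48 h (on this read-out higher numbers stand for weaker inhibition and lower numbers for stronger inhibition), compound 2 gives 3110 nM, the higher of the two numbers, so it is the weaker inhibitor of the pair. Compound 3 `COc1ccc(C(=O)c2ccc3c(c2)C=CC(C)(C)O3)c(NC(=O)CN(C)C)c1` has not yet been measured. It holds the same atoms as compound 2, joined differently: dimethylamino in place of ethylamino on a saturated chain carbon bound to a carbonyl carbon. In words, dimethylamino stands in place of ethylamino on a saturated chain carbon bound to a carbonyl carbon. Among the measured compounds shown here, only one measured step bears on this: a 3.2-fold higher number from compound 1 to compound 2 (0.51 log units; beyond the scatter). That step added a methyl, whereas here no atoms are added, so it is only a loose guide. A small move toward a lower number is expected, probably within the scatter, and the expected step in this assay is a 1.6-fold lower number from compound 2 to compound 3 (0.19 log units; within the scatter). The estimated value for compound 3 is 2000 nM, with an expected range from 700 nM to 6000 nM.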

Compound 3, half-maximal inhibitory concentration: 1260 nM
Beside the measured number, compound 3's estimate is 1.6-fold (0.20 log units) above it; the measured number falls inside the stated range.
By their numbers in this assay, from the lowest: compounds 1 and 3 (each within the scatter of the next); then compound 2.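

In this assay, rearranging the same atoms from ethylamino to dimethylamino gives a 2.5-fold lower number from compound 2 to compound 3 (0.39 log units; beyond the scatter) on this saturated chain carbon bound to a carbonyl carbon, so the arrangement of the atoms in this group matters and not only their number. The place of an added methyl also counts among these three compounds: on the amine nitrogen it gives a 1.3-fold higher number from compound 1 to compound 3 (0.11 log units; within the scatter) and leaves no readable change, whereas on the saturated chain carbon bound to the amine nitrogen it gives a 3.2-fold higher number from compound 1 to compound 2 (0.51 log units; beyond the scatter) and stands beyond the scatter. Nothing measured here explains why these arrangements differ. Still open, as far as these compounds go, is how a diethylamino group, a longer chain such as propylamino or a ring amine such as pyrrolidine would compare at this place.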